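The source may hold more compounds than are shown below. What is called first, only, known or untested is meant among the compounds shown, and "the series" means these compounds.

Compounds measured in a functional assay on CRL2813 cells (Homo sapiens) for cytotoxicity, read by sulforhodamine B assay, with a stated time of 5 days; on this read-out lower numbers stand for stronger inhibition and higher numbers for weaker inhibition:
Compound 1 `Cc1ccc(NC(=O)N[C@H]2CC[C@H](Oc3ccc(F)cc3)CC2)cc1` — in this assay compound 1 gives > 20000 nM, a limit of the assay.
Compound 2 `O=C(Nc1ccc(Br)cc1)N[C@H]1CC[C@H](Oc2ccc(F)cc2)CC1` — in this assay compound 2 gives > 20000 nM, also a limit.
Compound 3 `O=C(Nc1ccc([N+](=O)[O-])cc1)N[C@H]1CC[C@H](Oc2ccc(F)cc2)CC1` — in this assay compound 3 gives 2300 nM.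

For the measured compounds named here, compound 3 thus holds the only number; the other two values sit at the limit (the limit of > 20000 nM in this assay, at which 2 of the 3 values shown sit). Compound 4 `Cc1cccc(NC(=O)N[C@H]2CC[C@H](Oc3ccc(F)cc3)CC2)c1` differs from compound 3 by 3-methylphenyl in place of 4-nitrophenyl on an amide-type nitrogen. Going by the values given here, the steps that bear on this are an at least 8.6-fold lower number from compound 1 to compound 3 (0.93 log units; beyond the scatter) and an at least 8.6-fold lower number from compound 2 to compound 3 (0.93 log units; beyond the scatter); the step that the two limits leave unreadable from compound 1 to compound 2 is unreadable. Removing the nitro therefore is expected to reverse the gain, giving a step of an 11-fold higher number from compound 3 to compound 4 (1.04 log units; beyond the scatter) to a higher number. Compound 4 is estimated at 25000 nM, range 8000 nM to 80000 nM, most likely reported only as a limit.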

Compound 4, half-maximal inhibitory concentration: 14400 nM
Estimate against measurement, compound 4: 1.7-fold (0.24 log units) above; measured number inside the range.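

In this assay, for the compounds shown here, 3-methylphenyl on the amide-type nitrogen gives the first number without a nitro group, so the loss on leaving 4-nitrophenyl now has a size: a 6.3-fold higher number from compound 3 to compound 4 (0.80 log units; beyond the scatter). Against the two limits the steps are an at least 1.3-fold lower number from compound 2 to compound 4 (0.14 log units; that floor lies within the scatter) and an at least 1.3-fold lower number from compound 1 to compound 4 (0.14 log units; that floor lies within the scatter), and both floors lie within the scatter. The order among the compounds without nitro therefore stays unresolved: the limit of > 20000 nM in this assay, at which 2 of the 4 values shown sit.

Going by these compounds, whether a nitrile or a carboxylic acid in place of the nitro would keep the number of compound 3 remains open. So does the effect of an amine there.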